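Swapping the Sulfonylpiperidine for a Trifluoromethylcyclohexyl Group

The source may report more compounds than this note shows. Statements on the series, on what has been measured and on what is new or still open speak of the compounds shown alone.

Of the compounds shown here, three sharing one core have been measured in an assay on isolated protein for inhibition of histone acetyltransferase p300 (Homo sapiens), read by AlphaLISA, with a stated time of 20 min; a higher number here means a weaker inhibitor, a lower number a stronger inhibitor. Compound 1 `COc1ccc(CCc2nc3cc(-c4c(C)noc4C)ccc3n2[C@H]2CC[C@H](O)CC2)cc1Cl` gives 48 nM, compound 2 `COc1ccc(CCc2nc3cc(-c4c(C)noc4C)ccc3n2C2CCC(F)(F)CC2)cc1Cl` gives 83 nM, and compound 3 `COc1ccc(CCc2nc3cc(-c4c(C)noc4C)ccc3n2C2CCN(S(C)(=O)=O)CC2)cc1Cl` gives 148 nM, the highest number of the three, although only its gap to compound 1 lies beyond the scatter: there is a 3.1-fold higher number from compound 1 to compound 3 (0.49 log units; beyond the scatter) and a 1.8-fold higher number from compound 2 to compound 3 (0.25 log units; within the scatter). Compound 4 `COc1ccc(CCc2nc3cc(-c4c(C)noc4C)ccc3n2[C@H]2CC[C@H](C(F)(F)F)CC2)cc1Cl` differs from compound 3 by 4-(trifluoromethyl)cyclohexyl in place of 1-(methylsulfonyl)piperidin-4-yl on an aromatic nitrogen. Among the compounds with values here, the step from compound 2 to compound 3 is the closest precedent, as it exchanged a ring of carbon only for the same sulfonylpiperidine; walking back toward a ring of carbon only points to a lower number, though that step itself stayed within the scatter. Compound 4 is therefore expected to give 70 nM (range 30 nM to 160 nM), an estimated 2.1-fold lower number from compound 3 to compound 4 (0.33 log units; beyond the scatter) in this assay.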

Compound 4, half-maximal inhibitory concentration: 894 nM
Compound 4: middle estimate off by 13-fold (1.11 log units), on the low side; measured number outside the range, above it.
By their numbers in this assay, from the lowest: compounds 1, 2 and 3 (each within the scatter of the next, the first and the last beyond it); then compound 4.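

In this assay the 4-(trifluoromethyl)cyclohexyl group parts from the other ring of carbon only, with an 11-fold higher number from compound 2 to compound 4 (1.03 log units; beyond the scatter) at this place on the aromatic nitrogen, so a ring of carbon only does not by itself keep the number low. The same group also falls behind 1-(methylsulfonyl)piperidin-4-yl, with a 6.0-fold higher number from compound 3 to compound 4 (0.78 log units; beyond the scatter) here, and trifluoromethyl in place of hydroxy gives a 19-fold higher number from compound 1 to compound 4 (1.27 log units; beyond the scatter) on the same saturated ring carbon. Nothing available explains these steps. On these data alone, whether an amine or a carboxylic acid on that ring carbon would read nearer compound 1 or compound 4 stays open.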